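The source may hold more compounds than are shown below. What is called first, only, known or untested is meant among the compounds shown, and "the series" means these compounds.

Measured compounds in a functional assay on CFPAC-1 cells (Homo sapiens) for inhibition, read by MTT assay, with a stated time of 72 h; a lower number here means a stronger inhibitor, a higher number a weaker inhibitor:

Compound 1 `O=c1cc(Cn2cc(C3CC3)nn2)c2ccc(O)cc2o1` gives > 100000 nM in this assay, which is a limit of the assay. Compound 2 `CC(O)c1cn(Cc2cc(=O)oc3cc(O)ccc23)nn1` gives > 100000 nM, again a limit. Compound 3 `CC(C)(C)c1cn(Cc2cc(=O)oc3cc(O)ccc23)nn1` gives > 100000 nM, also a limit.

Compound 3 thus stands at the edge of what this assay can report, and it is not alone there, because all three values sit at the limit of > 100000 nM in this assay, at which 3 of the 3 values shown sit. The steps among these compounds are accordingly unreadable: a step that the two limits leave unreadable from compound 1 to compound 2, a step that the two limits leave unreadable from compound 1 to compound 3 and a step that the two limits leave unreadable from compound 2 to compound 3. None of them gives a size or a direction.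

Compound 4 `CCCCCCc1cn(Cc2cc(=O)oc3cc(O)ccc23)nn1` differs from compound 3 by hexyl in place of tert-butyl on an aromatic carbon. The measured steps that touch this position, a step that the two limits leave unreadable from compound 1 to compound 3 and a step that the two limits leave unreadable from compound 2 to compound 3, have no readable size, so they offer no ground for expecting a step beyond the scatter in this assay in either direction. The step expected here, a number no higher from compound 3 to compound 4 (the limit leaves the size open), is therefore none beyond the scatter. Compound 4 is estimated at 100000 nM, with a range from 30000 nM to 300000 nM, and most likely the assay will again report a limit rather than a number.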

Compound 4, half-maximal inhibitory concentration: > 100000 nM
Compound 4 ended at the assay's limit; the forecaster's own chance of this, stated with the estimate: 80%; the middle value lies on the limit itself.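

Among the compounds shown here, compound 4 gives > 100000 nM in this assay, again a limit, so no step from compound 1, compound 2 or compound 3 to compound 4 can be read: the limit of > 100000 nM in this assay, at which 4 of the 4 values shown sit.

The compounds shown leave open whether any of these groups on the triazole-bearing position changes the inhibition at all, and by how much.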